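Trimethoxy to dimethoxy on the pyrazole-attached ring

The source may hold more compounds than are shown below. What is called first, only, known or untested is meant among the compounds shown, and "the series" means these compounds.

The series is built around a pyrazole carrying an aryl ring on one side and an enone on the other. Compound 1 `COc1cc(-c2cc(/C=C/C(=O)c3ccc(N)cc3)[nH]n2)cc(OC)c1OC` carries three methoxy groups on the pyrazole-attached ring and an aminophenyl ketone; in a functional assay on CCRF-CEM cells (Homo sapiens) for cytotoxicity, read by sulforhodamine B assay, with a stated time of 48 h, tested at 1 uM (on this read-out lower numbers stand for a stronger effect and higher numbers for a weaker effect at the one concentration tested), compound 1 gives 36%. Compound 2 `COc1ccc(-c2cc(/C=C/C(=O)c3ccc(N)cc3)[nH]n2)cc1OC` differs from it by hydrogen in place of methoxy on an aromatic carbon, and in this assay compound 2 gives 68%. This step is a number 32 percentage points higher from compound 1 to compound 2 (beyond the scatter), a clear loss of effect at the single concentration tested.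

Compound 3 `COc1cc(C(=O)/C=C/c2cc(-c3cc(OC)c(OC)c(OC)c3)n[nH]2)cc(OC)c1OC` keeps the trimethoxyphenyl pyrazole but carries a trimethoxyphenyl ketone instead of the aminophenyl ketone; the difference between the core of compound 3 and the core of compound 1 is not broken down here. In this assay compound 3 gives 67%, a value within the scatter of compound 2 and well weaker than compound 1.

Compound 4 `COc1ccc(-c2cc(/C=C/C(=O)c3cc(OC)c(OC)c(OC)c3)[nH]n2)cc1OC`, not yet measured, differs from compound 3 by hydrogen in place of methoxy on an aromatic carbon. The place of the change is the same as from compound 1 to compound 2, so this is the same change on the other ketone. Within the data shown here, the step from compound 3 to compound 4 in this assay is expected to be a number 23 percentage points higher from compound 3 to compound 4 (beyond the scatter), resting on the single precedent a number 32 percentage points higher from compound 1 to compound 2 (beyond the scatter) and on compound 3 already starting at 67%, which leaves less room for a further rise. Compound 4 is therefore estimated at 90%, with a range from 68% to 108%.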

Compound 4, a percentage reported as activity, at one concentration (the size of the read-out at that concentration, not a potency): 14%
Beside the measured number, compound 4's estimate is 76 percentage points above it; the whole stated range lies above it.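

In this assay, hydrogen in place of methoxy on an aromatic carbon gives a number 53 percentage points lower from compound 3 to compound 4 (beyond the scatter), a stronger effect at the one concentration tested. Set against the same change on the aminophenyl ketone, this step runs the opposite way, so neither its size nor its direction carries from the core of compound 1 to the core of compound 3: the same change on two cores in this assay, a number 32 percentage points higher (beyond the scatter) from compound 1 to compound 2 and a number 53 percentage points lower (beyond the scatter) from compound 3 to compound 4, 85 percentage points apart, beyond the scatter of two such steps The reversal shows that the outcome of removing this methoxy depends on the rest of the molecule, but it rests on only two steps, each read at a single concentration, and it shows neither the reason for the reversal nor what a further core would do.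

On these data alone, it remains open whether the direction of the step follows the amine of the aminophenyl ketone, the methoxy groups of the trimethoxyphenyl ketone, or both together. Ketone aryl rings carrying a carboxylic acid or a hydroxy group in place of those groups, and an ethoxy group in place of the methoxy that leaves, would show whether the reversal is specific to these two cores or extends across the wider series.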